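From 2-Fluorophenoxy to 3-Chlorophenoxy on a Shared Core

The source may report more compounds than this note shows. Statements on the series, on what has been measured and on what is new or still open speak of the compounds shown alone.

Compound 2 `Cc1nn(C)c(Oc2ccccc2F)c1/C=N\CCCCCCOc1cc2oc(=O)cc(C)c2cc1Cl` was examined in a functional assay on U-87MG ATCC cells for antiproliferative activity against U-87 MG (Homo sapiens), read by MTT assay, with a stated time of 72 h; on this read-out higher numbers stand for weaker inhibition and lower numbers for stronger inhibition. In this assay compound 2 gives > 25000 nM, which is a limit of the assay and not a number. A second member of the series, compound 1 `Cc1nn(C)c(Oc2ccc(I)cc2)c1/C=N\CCCCCOc1cc2oc(=O)cc(C)c2cc1Cl`, is also measured. In this assay compound 1 gives > 25000 nM, again a limit rather than a number. Among the compounds with values here, both readings thus sit at the limit of > 25000 nM in this assay, at which 2 of the 2 values shown sit, and no step between measured compounds that differ in a single place can be drawn from them.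

Compound 3 `Cc1nn(C)c(Oc2cccc(Cl)c2)c1/C=N\CCCCCCOc1cc2oc(=O)cc(C)c2cc1Cl` has not been measured. Its change from compound 2 is 3-chlorophenyl in place of 2-fluorophenyl on an oxygen on an aromatic ring. With both measured values resting at the limit of > 25000 nM in this assay, at which 2 of the 2 values shown sit, there is no basis for expecting a step beyond the scatter in either direction in this assay. The step expected in this assay is a step that the limit leaves unreadable from compound 2 to compound 3, and the result is expected most likely to appear once more as a limit. Compound 3 is estimated to give 30000 nM in this assay, with an expected range from 8000 nM to 100000 nM.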

Compound 3, half-maximal inhibitory concentration: 8460 nM
Compound 3: the middle estimate sits 3.5-fold (0.55 log units) above what was measured; the range from low to high includes it.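

In this assay, 3-chlorophenyl in place of 2-fluorophenyl on an oxygen on an aromatic ring gives an at least 2.9-fold lower number from compound 2 to compound 3 (0.47 log units; beyond the scatter), which shows that the group at this place can move the read-out beyond the usual scatter. Within the data shown here, compound 3 also supplies the first value in this small set that is a number rather than a limit, so activity on the shared core can now be read at all. The step can be stated only as a minimum because compound 2 sits at a limit of the assay, and its true size remains unknown: the limit of > 25000 nM in this assay, at which 2 of the 3 values shown sit.

The change replaces fluorine with chlorine and also alters the place of the halogen on the ring, so the compounds shown do not separate these two contributions to the step. They also leave open how a plain phenyl, a methoxyphenyl or a pyridine ring would read on the same oxygen, and whether an amine or a carboxylic acid on that ring would keep, extend or lose what compound 3 shows.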